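Swapping an Isobutyl for a Hydroxyethyl on a Sulfonamide

A few compounds are considered here, and "the series" means these few. Any claim that something is new, unique, unknown or untested is made for them only; others in the source may bear on it.

Of the compounds shown here, two have been measured in a functional assay on K562 cells (Homo sapiens) for antiproliferative activity, read by CCK-8 assay, with a stated time of 72 h; a lower number here means a stronger inhibitor of growth, a higher number a weaker inhibitor of growth. Compound 1 `CC[C@@H]1C(=O)N(C)c2cnc(Nc3ccc(S(=O)(=O)NCCO)cc3)nc2N1C1CCCC1` gives 546 nM in this assay. Compound 2 `CCC1C(=O)N(C)c2cnc(Nc3ccc(S(=O)(=O)NCC(C)C)cc3)nc2N1c1ccn(C)n1` gives 7300 nM in this assay, the higher of the two numbers, so compound 2 is the weaker growth inhibitor, and the gap between the two numbers lies beyond the usual scatter. Compound 3 `CCC1C(=O)N(C)c2cnc(Nc3ccc(S(=O)(=O)NCCO)cc3)nc2N1c1ccn(C)n1` has not been measured yet. It differs from compound 2 in one place: hydroxymethyl in place of isopropyl on a saturated chain carbon bound to a sulfonamide nitrogen. The (2-hydroxyethyl)sulfamoyl group that enters is the same one that compound 1 carries, although compound 1 and compound 3 differ in another part of the shared core, so the value of compound 1 cannot simply be transferred. Among the compounds with values here, no step between measured compounds that differ in only one place is available, so there is no direct precedent for this change. Because compound 1 with that same entering group gives 546 nM, compound 3 is expected to give a lower number than compound 2, by an estimated step of a 2.9-fold lower number from compound 2 to compound 3 (0.47 log units; beyond the scatter) in this assay. The estimate for compound 3 is 2500 nM, with an expected range from 800 nM to 8000 nM.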

Compound 3, concentration for 50% growth inhibition: "not active" (no number reported)
Compound 3 has no reported number here; the estimate stays without a comparison.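

In this assay, within the data shown here, compound 3 is reported as "not active" with no number, so no step from compound 2 to compound 3 can be read. The compounds shown leave open how much the change from isobutyl to 2-hydroxyethyl alone shifts growth inhibition. No measured evidence here bears on this result.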